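This account rests on a few compounds, and the source may have more. Where it says the series, first, only, none or still open, it means among the compounds named here.

Compound 1 `O=C(CSc1nnnn1-c1ccccc1)N/N=c1/scc(-c2ccc(Cl)cc2)n1-c1ccccc1` is the point of departure. In a functional assay on C6 cells (Rattus norvegicus) for cytotoxicity, read by MTT assay, with a stated time of 24 h (on this read-out lower numbers stand for stronger inhibition and higher numbers for weaker inhibition), compound 1 gives only a limit, > 200 ug/mL, which places it at the weak end of the numbers shown (the limit of > 200 ug/mL in this assay, at which 1 of the 2 values shown sits). Compound 2 `O=C(CSc1nnnn1-c1ccccc1)N/N=c1/scc(-c2ccc(F)cc2)n1-c1ccccc1` gives 24.3 ug/mL in this assay, a step of an at least 8.2-fold lower number from compound 1 to compound 2 (0.91 log units; beyond the scatter). Compound 3 `O=C(CSc1ncccn1)N/N=c1/scc(-c2ccc(Cl)cc2)n1-c1ccccc1` differs from compound 1 by pyrimidin-2-yl in place of 1-phenyl-1H-tetrazol-5-yl on a sulfur. Within the data shown here, no measured step touches the group on the sulfur, so the one measured step gives no guide to its size or direction. The estimate for compound 3 is 150 ug/mL, expected between 40 ug/mL and 400 ug/mL. That would be an expected step of an at least 1.3-fold lower number from compound 1 to compound 3 (0.12 log units; that floor lies within the scatter).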

Compound 3, half-maximal inhibitory concentration: 83.3 ug/mL
Compound 3: middle estimate off by 1.8-fold (0.26 log units), on the high side; the range from low to high includes it.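

Changing the group on the sulfur moves the number in this assay: pyrimidin-2-yl in place of 1-phenyl-1H-tetrazol-5-yl gives an at least 2.4-fold lower number from compound 1 to compound 3 (0.38 log units; beyond the scatter). This place, which the earlier fluoro in place of chloro step left untouched, therefore also responds, with the chloro group kept. The true size of the step stays unknown, because its starting point is only a limit: the limit of > 200 ug/mL in this assay, at which 1 of the 3 values shown sits.

The compounds shown leave open how pyrimidin-2-yl behaves together with fluoro. They also leave open whether a non-aromatic group on the sulfur, such as a methyl or an aminoethyl chain, would give a comparable number.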